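Swapping Chloro for Fluoro on a Cytotoxic Core

The source may report more compounds than this note shows. Statements on the series, on what has been measured and on what is new or still open speak of the compounds shown alone.

Measured so far:
compound 1, `O=C(Nn1c(-c2cccc([N+](=O)[O-])c2)nc2c(-c3cccc(Cl)c3)n[nH]c2c1=O)c1ccccc1` — 93.8%
compound 2, `O=C(Nn1c(-c2cccc([N+](=O)[O-])c2)nc2c(-c3ccc(Cl)cc3)n[nH]c2c1=O)c1ccccc1` — 94.3%

In a functional assay on DU-145 cells (Homo sapiens) for cytotoxicity, read by sulforhodamine B assay, with a stated time of 2 days, tested at 100 uM (a higher number here means more inhibition at the concentration tested (going by the name of the read-out), a lower number less inhibition), compound 1 gives 93.8%, and compound 2 gives 94.3%. Going by the values given here, the one change between them, a number 0.5 percentage points higher from compound 1 to compound 2 (within the scatter), shows that moving the chloro around its ring leaves the read-out essentially unchanged; compound 2 and compound 1 sit within the scatter of each other, with the number level between them.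

Compound 3, `O=C(Nn1c(-c2cccc([N+](=O)[O-])c2)nc2c(-c3ccc(F)cc3)n[nH]c2c1=O)c1ccccc1`, differs from compound 2 by fluoro in place of chloro on an aromatic carbon. Among the compounds with values here, no measured step exchanges one halogen for another, so the only guide is that both measured compounds sit at the ceiling of this assay and that the single halogen rearrangement barely moved the number. Compound 3 is therefore expected to stay close to compound 2, with a step of about a number 4.3 percentage points lower from compound 2 to compound 3 (within the scatter). The estimate for compound 3 is 90%, ranging from 76% to 98%.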

Compound 3, a percentage reported as inhibition, at one concentration (the size of the read-out at that concentration, not a potency): 90.8%
The estimate for compound 3 lay 0.8 percentage points below the measured number; the range from low to high includes it.
By their numbers in this assay, from the lowest: compounds 3, 1 and 2 (each within the scatter of the next).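

The earlier compounds shown here only moved a chloro around its ring, whereas compound 3 exchanges the halogen itself, and in this assay that exchange at this place, para to a large group, gives a number 3.5 percentage points lower from compound 2 to compound 3 (within the scatter). Changing both the halogen and its place on the ring at once gives a number 3 percentage points lower from compound 1 to compound 3 (within the scatter), so neither kind of change separates the three compounds in this read-out. No measured evidence bears on why the number stays level.

All three compounds carry a single halogen on this phenyl ring, so an amine, a carboxylic acid or a longer chain at the same place remains an open test. Going by these compounds, with all three high in a read-out taken at one concentration, any difference in potency between them also remains open.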